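Methyl for Hydroxy on the Fused Core: Efficacy Outlook

The compounds below may be only part of what the source reports. "The series", "measured", "known", "first", "only" and "open" are said of these compounds alone.

Three measured compounds frame the question. In a functional assay on Urethra with Alpha-1A adrenergic receptor (Oryctolagus cuniculus) as the target (on this read-out higher numbers stand for larger maximal responses and lower numbers for smaller maximal responses), compound 1 `CS(=O)(=O)Nc1ccc(O)c2c1CCCC2c1c[nH]cn1` gives 34%, the lowest of the three values. Compound 2 `CCS(=O)(=O)Nc1cccc(Cc2c[nH]cn2)c1C` gives 69% in this assay, and compound 3 `Nc1cccc2c1CCCC2c1c[nH]cn1` gives 84%, both lying beyond the scatter above compound 1. Among the compounds with values here, neither pair differs in a single place, so no measured step guides the next move.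

Compound 4 `Cc1ccc(NS(C)(=O)=O)c2c1C(c1c[nH]cn1)CCC2` differs from compound 1 by methyl in place of hydroxy on an aromatic carbon. The account expects a step of a number 21 percentage points higher from compound 1 to compound 4 (beyond the scatter) that is upward and beyond the scatter, since the two higher-efficacy compounds lack the hydroxy group, though neither is a direct match. Compound 4 is therefore estimated at 55%, with a range from 30% to 80%.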

Compound 4, largest response reached (reported as efficacy), in percent of the reference or control that the assay uses: 35%
Compound 4: the middle estimate sits 20 percentage points above what was measured; low and high end bracket the measured number.
By their numbers in this assay, from the lowest: compounds 1 and 4 (each within the scatter of the next); then compound 2; then compound 3.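

In this assay the exchange of hydroxy for methyl, para to the methanesulfonamido group, gives a number 1 percentage points higher from compound 1 to compound 4 (within the scatter) and so leaves the maximal response unresolved between the two groups. Within the data shown here, this is the first comparison here that isolates a single place, and at this position on the shared core, either hydroxy or methyl is compatible with the same response. Nothing available explains this result. As far as these compounds go, it remains open whether an amine, a methoxy group or a fluorine at this aromatic carbon would give a step beyond the scatter.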